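Replacing Chloro with tert-Butyl: From Compound 3 to Compound 4

A few compounds are considered here, and "the series" means these few. Any claim that something is new, unique, unknown or untested is made for them only; others in the source may bear on it.

In a functional assay on the whole organism for inhibition, with Mus musculus as the target, at a dose of 1 mg/kg by the oral route (on this read-out lower numbers stand for less inhibition and higher numbers for more inhibition at the one dose given (going by the name of the read-out)), compound 3 `COc1cccc2c1c(O)c(C(=O)N(C)c1cccc(Cl)c1)c(=O)n2C` gives 85%, the highest of the three numbers; compound 1 `COc1cccc2c1c(O)c(C(=O)N(C)c1ccccc1F)c(=O)n2C` gives 82%, which lies within the scatter of compound 3, while compound 2 `COc1cccc2c1c(O)c(C(=O)N(C)c1c(F)cccc1F)c(=O)n2C` gives 43%. The measured steps show that a change on the aryl ring can matter: a number 39 percentage points lower from compound 1 to compound 2 (beyond the scatter), and a number 42 percentage points higher from compound 2 to compound 3 (beyond the scatter), whereas a number 3 percentage points higher from compound 1 to compound 3 (within the scatter). Compound 4 `COc1cccc2c1c(O)c(C(=O)N(C)c1cccc(C(C)(C)C)c1)c(=O)n2C` differs from compound 3 by tert-butyl in place of chloro on an aromatic carbon. Within the data shown here, no measured step exchanges these two groups, so the expectation rests only on the observation that the number stays level across one pair of patterns on the ring and falls for another. A modest drop in this assay is estimated, a number 15 percentage points lower from compound 3 to compound 4 (beyond the scatter), and compound 4 is expected to give about 70%, between 35% and 95%.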

Compound 4, a percentage reported as inhibition, in the whole organism at one dose (the size of the read-out at that dose, not a potency): 60%
Compound 4: middle estimate off by 10 percentage points, on the high side; measured number inside the range.
By their numbers in this assay, from the lowest: compound 2; then compound 4; then compounds 1 and 3 (each within the scatter of the next).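

Among these compounds, at this place, meta to a large group, the earlier compounds carried only halogens, and tert-butyl is the first carbon group there. In this assay it gives a number 25 percentage points lower from compound 3 to compound 4 (beyond the scatter), so the number does respond to the group exchanged at this position, and a larger group still leaves clear inhibition at the one dose. Nothing measured here bears on the reason for this step.

The compounds shown leave open whether a methyl group, a methoxy group or an amine at this place would stay level with compound 3. They also leave open whether tert-butyl would give the same step elsewhere on the ring.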